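The compounds below may be only part of what the source reports. "The series", "measured", "known", "first", "only" and "open" are said of these compounds alone.

In an ADME assay on microsomes from liver (Homo sapiens) for metabolic stability, read by LC-MS, with a stated time of 10 min (on this read-out lower numbers stand for a less stable compound and higher numbers for a more stable compound), three compounds have been measured:

compound 1 `CN(C[C@H]1Cc2c(cccc2N2CCN(C3CC3)CC2)CN1)[C@H]1CCCc2cccnc21` gives 15.5%
compound 2 `Cc1cnc2c(c1)CCC[C@@H]2N(C)C[C@H]1Cc2c(cccc2N2CCNCC2)CN1` gives 47.8%
compound 3 `CC(C)N(C[C@H]1Cc2c(cccc2N2CCNCC2)CN1)[C@H]1CCCc2cccnc21` gives 75%

Compound 1 stands lowest of the three numbers. Its nearest neighbour is compound 2, whose number is higher by an amount beyond the scatter, and compound 3 stands furthest, higher still by an amount beyond the scatter. No pair of these compounds differs in only one place, so their values show only that compound 1 is the least stable of the three in this assay and compound 3 the most stable.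

The step followed here goes from compound 1 to compound 4 `C[C@@H]1CN(c2cccc3c2C[C@H](CN(C)[C@H]2CCCc4cccnc42)NC3)C[C@H](C)N1C`, which has not yet been measured in this assay. The change is 3,4,5-trimethylpiperazin-1-yl in place of 4-cyclopropylpiperazin-1-yl on an aromatic carbon. Both groups carry the same count of heavy atoms and acceptors and no donors; the group that enters brings two defined stereocentres and loses the three-membered ring.

Within the data shown here, no measured step of this kind is on record. Since compound 1 sits at the bottom of a spread in which compounds 2 and 3 stand well higher, an upward step of modest size is expected, a number 14.5 percentage points higher from compound 1 to compound 4 (beyond the scatter), though a result within the scatter would not surprise. Compound 4 is thus estimated at 30%, with a range from 10% to 60%.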

Compound 4, percent of the compound remaining: 24.6%
Compound 4: middle estimate off by 5.4 percentage points, on the high side; the measured number falls inside the stated range.
By their numbers in this assay, from the lowest: compounds 1 and 4 (each within the scatter of the next); then compound 2; then compound 3.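

Among these compounds, this is the first step in the set that changes one place only. In this assay, putting 3,4,5-trimethylpiperazin-1-yl in place of 4-cyclopropylpiperazin-1-yl on the aromatic carbon gives a number 9.1 percentage points higher from compound 1 to compound 4 (within the scatter) and leaves the two compounds indistinguishable on this read-out, so this exchange, which removes the three-membered ring and brings in two defined stereocentres while keeping the same counts of heavy atoms and acceptors, does not separate them. Nothing on record explains this result or connects it to any feature of either group.

Among the compounds shown here, the single step changes several features together, so it cannot show what the loss of the cyclopropyl ring contributes apart from the added methyl groups and their stereocentres; 4-methylpiperazin-1-yl at the same aromatic carbon on the core of compound 1 would bear on that question. As far as these compounds go, it also remains open whether a more different group at this carbon, such as morpholin-4-yl or 4-acetylpiperazin-1-yl, would give a step beyond the scatter from compound 1 in this assay on the same core.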